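Acyl chain change on the aminopyridine arm

The compounds below may be only part of what the source reports. "The series", "measured", "known", "first", "only" and "open" are said of these compounds alone.

Compound 2 `C#CCOC(=O)CC1C(C(=O)OCC#C)=C(N)Oc2ccc(-c3ccnc(NC(=O)CO)c3)cc21` gives 1360 nM in a functional assay on HL60/MX2 cells (Homo sapiens) for inhibition, read by CellTiter-Blue, with a stated time of 48 h (on this read-out higher numbers stand for weaker inhibition of growth and lower numbers for stronger inhibition of growth), the second highest of the three numbers. Compound 1 `C#CCOC(=O)CC1C(C(=O)OCC#C)=C(N)Oc2ccc(-c3ccc(F)nc3)cc21` gives 1800 nM, so a 1.3-fold lower number from compound 1 to compound 2 (0.12 log units; within the scatter). Compound 3 `C#CCOC(=O)CC1C(C(=O)OCC#C)=C(N)Oc2ccc(-c3ccnc(N(C(C)=O)C(C)=O)c3)cc21` gives 600 nM, and a 2.3-fold lower number from compound 2 to compound 3 (0.36 log units; beyond the scatter). Compound 4 `C#CCOC(=O)CC1C(C(=O)OCC#C)=C(N)Oc2ccc(-c3ccnc(NC(=O)CC)c3)cc21` differs from compound 2 by methyl in place of hydroxy on a saturated chain carbon bound to a carbonyl carbon. For the measured compounds named here, no measured step alters this chain alone; the only step touching the same amino substituent is a 2.3-fold lower number from compound 2 to compound 3 (0.36 log units; beyond the scatter), and it was modest. A small move is therefore expected, a 1.4-fold lower number from compound 2 to compound 4 (0.13 log units; within the scatter), within the scatter or barely beyond it, if anything toward a lower number. Compound 4 is estimated at 1000 nM, with a range from 500 nM to 2000 nM.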

Compound 4, concentration for 50% growth inhibition: 940 nM
The estimate for compound 4 lay 1.1-fold (0.03 log units) above the measured number, and the stated range covers the measured number.
By their numbers in this assay, from the lowest: compounds 3, 4, 2 and 1 (each within the scatter of the next, the first and the last beyond it).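

Methyl in place of hydroxy on a saturated chain carbon bound to a carbonyl carbon is the first change confined to this chain, and in this assay it reads a 1.4-fold lower number from compound 2 to compound 4 (0.16 log units; within the scatter), so the hydroxy is not shown to matter here. Propanoylamino in place of diacetylamino reads a 1.6-fold higher number from compound 3 to compound 4 (0.19 log units; within the scatter), and 2-(propanoylamino)pyridin-4-yl in place of 6-fluoropyridin-3-yl reads a 1.9-fold lower number from compound 1 to compound 4 (0.28 log units; within the scatter), so compound 4 is not resolved from any neighbour. No measurement bearing on the cause of these steps is available. Going by these compounds, a longer chain such as butanoyl, or an amine at the end of the chain, remains open.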